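Removing the Ring Methyl of Compound 1

The source may report more compounds than this note shows. Statements on the series, on what has been measured and on what is new or still open speak of the compounds shown alone.

Compound 1 `COc1ccccc1/C=c1/[nH]c(=O)/c(=C\c2ccccc2OC)n(C)c1=O` gives 9000 nM in a functional assay on MCF7 cells (Homo sapiens) for cytotoxicity, read by CCK-8 assay, with a stated time of 72 h (a higher number here means a weaker inhibitor, a lower number a stronger inhibitor), the highest of the three numbers shown. Going by the values given here, compound 3 `C=CCn1c(=O)/c(=C\c2cc(F)ccc2C)[nH]c(=O)/c1=C\c1ccccc1OC` gives 3100 nM and compound 2 `COc1ccccc1/C=c1\c(=O)[nH]/c(=C/c2cccc(Cl)c2Cl)c(=O)n1C` gives 200 nM; the step of a 45-fold lower number from compound 1 to compound 2 (1.65 log units; beyond the scatter) is the only single-place change recorded, and it concerns a different site from the ring nitrogen. Compound 4 `COc1ccccc1/C=c1/[nH]c(=O)/c(=C\c2ccccc2OC)[nH]c1=O` differs from compound 1 by hydrogen in place of methyl on an aromatic nitrogen. Among the compounds with values here, no measured pair isolates this change, and compound 3 differs from compound 1 in more than one place, so no recorded step bears directly on it. The expectation is therefore a step of no change at the digits printed from compound 1 to compound 4 (within the scatter), within the scatter, with no direction favoured. Compound 4 is thus estimated at 9000 nM in this assay, with a range from 3000 nM to 27000 nM.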

Compound 4, half-maximal inhibitory concentration: "not active" (no number reported)
The entry for compound 4 holds no number, so the estimate cannot be set against anything.
By their numbers in this assay, from the lowest: compound 2; then compound 3; then compound 1.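

In this assay, going by these compounds alone, compound 4 is entered as "not active" with no number, so no step from compound 1 to compound 4 can be read. No evidence shown bears on this result. The compounds shown leave open how far hydrogen in place of methyl on the aromatic nitrogen shifts the number.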